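Benzyl to allyl in compound 1: an untested change

The source may report more compounds than this note shows. Statements on the series, on what has been measured and on what is new or still open speak of the compounds shown alone.

Compound 1 `O=c1c(-c2cccc([N+](=O)[O-])c2)nc2ccccc2n1Cc1ccccc1` has the lowest number of the two that were measured: in an assay on cells for activation of Cystic fibrosis transmembrane conductance regulator (Homo sapiens), read by fluorescence, with a stated time of 10 min (a lower number here means that less compound is needed, a higher number that more compound is needed for the effect), compound 1 gives 9 nM. Compound 2 `O=c1c(-c2cccc(Br)c2)nc2ccccc2n1Cc1ccccc1` gives 330 nM in this assay, a change of a 37-fold higher number from compound 1 to compound 2 (1.56 log units; beyond the scatter). Compound 3 `Cc1cccc2nc(-c3cccc([N+](=O)[O-])c3)c(=O)n(Cc3ccccc3)c12` gives only a limit of this assay, > 10000 nM. That step is an at least 1100-fold higher number from compound 1 to compound 3 (3.04 log units; beyond the scatter). Compound 4 `C=CCn1c(=O)c(-c2cccc([N+](=O)[O-])c2)nc2ccccc21` differs from compound 1 by vinyl in place of phenyl on a saturated chain carbon bound to an aromatic nitrogen. Neither measured step touches this group: one replaces the nitro group, the other adds a methyl to the core, so the size of the step to compound 4 cannot be read from them. Compound 4 is estimated at 60 nM, within 10 nM to 400 nM, so the expected step is a 6.7-fold higher number from compound 1 to compound 4 (0.82 log units; beyond the scatter), held with a wide range.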

Compound 4, half-maximal effective concentration: 55 nM
Estimate against measurement, compound 4: 1.1-fold (0.04 log units) above; measured number inside the range.
By their numbers in this assay, from the lowest: compound 1; then compound 4; then compound 2. At a limit, above all of these: compound 3.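

Replacing benzyl with allyl, the only change shown at this place, gives a 6.1-fold higher number from compound 1 to compound 4 (0.79 log units; beyond the scatter) in this assay. The ring of the benzyl group therefore helps but is not essential: compound 4, which has no ring there, still gives 55 nM as its value. Nothing shown here explains the size of this step.

Still open, as far as these compounds go, is whether the double bond of the allyl group matters, which a saturated propyl chain at this place would test. Also open, from the compounds shown here alone, is how a benzyl group carrying a methoxy group would compare.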